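Swapping an Amide Substituent and Watching Cytotoxicity

This account rests on a few compounds, and the source may have more. Where it says the series, first, only, none or still open, it means among the compounds named here.

Of the compounds shown here, three that share one core have been tested in an ADME assay on HepG2 2.2.15 cells (Homo sapiens) for cytotoxicity; a lower number here means that less compound is tolerated, a higher number that more compound is tolerated. Compound 1 `O=C(Nc1ncc(C(Oc2ccc3cc(Br)ccc3c2)c2ccc(Cl)cc2)s1)c1cccs1` is recorded there as "not toxic" (no number reported). Compound 2 `CCCCCC(=O)Nc1ncc(C(Oc2ccc3cc(Br)ccc3c2)c2ccc(Cl)cc2)s1` reaches only the limit of the assay, > 50000 nM, so no number is known for it. Compound 3 `CCN(CC)C(=O)Nc1ncc(C(Oc2ccc3cc(Br)ccc3c2)c2ccc(Cl)cc2)s1` likewise stands as "not toxic" (no number reported) in this assay, again without a single number. None of the three therefore gives a figure that could be ranked: one sits at the limit described by the limit of > 50000 nM in this assay, at which 1 of the 3 values shown sits, and the other two carry only the word that they are tolerated. Compound 4 `COc1ccc(C(=O)Nc2ncc(C(Oc3ccc4cc(Br)ccc4c3)c3ccc(Cl)cc3)s2)cc1` has not yet been measured. It differs from compound 3 in one place: 4-methoxyphenyl in place of diethylamino on a carbonyl carbon. For the measured compounds named here, with no measured step to lean on, no shift beyond the usual scatter is expected in this assay, and the most likely outcome is once more a limit rather than a number. Compound 4 is accordingly estimated at about 60000 nM, within a range from 20000 nM to 200000 nM.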

Compound 4, half-maximal cytotoxic concentration: > 50000 nM
Compound 4 gave a limit, no number; the forecaster's own chance of this, stated with the estimate: 80%; the middle value does not contradict the limit.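

Compound 2 and compound 4 each end at a limit of the assay rather than a number, so no step can be read between them: the limit of > 50000 nM in this assay, at which 2 of the 4 values shown sit.

The compounds shown leave open whether swapping the group on the carbonyl carbon changes the tolerated concentration in this assay at all.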